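A few compounds are considered here, and "the series" means these few. Any claim that something is new, unique, unknown or untested is made for them only; others in the source may bear on it.

Compound 1 `C=C(C)[C@@H]1CC=C(Cn2cc(COc3ccc(C4NC(=O)NC(C)=C4C(=O)OCC)cc3)nn2)CC1` and compound 3 `C=C(C)[C@@H]1CC=C(Cn2cc(COc3ccc(C4NC(=O)NC(C)=C4C(C)=O)cc3)nn2)CC1` share the same core and differ in a single place: methyl in place of ethoxy on a carbonyl carbon. In an ADME assay on HaCaT cells (Homo sapiens) for inhibition, read by sulforhodamine B assay, with a stated time of 48 h (on this read-out lower numbers stand for stronger inhibition of growth and higher numbers for weaker inhibition of growth), compound 1 gives 166000 nM, while compound 3 gives 44500 nM; the change made a 3.7-fold lower number from compound 1 to compound 3 (0.57 log units; beyond the scatter), so compound 3 inhibits growth more strongly. Compound 2 `C=C(C)[C@@H]1CC=C(Cn2cc(COc3cccc(C4NC(=O)NC(C)=C4C(=O)OCC)c3)nn2)CC1` is made of the same atoms as compound 1 joined differently; the difference between the two cores is not broken down here. In this assay compound 2 gives 508000 nM, the highest of the three numbers, which means the weakest inhibition of growth among them. Compound 4 `C=C(C)[C@@H]1CC=C(Cn2cc(COc3cccc(C4NC(=O)NC(C)=C4C(C)=O)c3)nn2)CC1` has not yet been measured. It differs from compound 2 exactly as compound 3 differs from compound 1: methyl in place of ethoxy on a carbonyl carbon, at the very same place. Because the same change on the core of compound 1 gave a 3.7-fold lower number from compound 1 to compound 3 (0.57 log units; beyond the scatter), compound 4 is expected to show a 3.7-fold lower number from compound 2 to compound 4 (0.57 log units; beyond the scatter) in this assay. The estimated value for compound 4 is therefore 137000 nM, with a likely range from 60000 nM to 310000 nM.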

Compound 4, concentration for total growth inhibition: 116000 nM
Compound 4: middle estimate off by 1.2-fold (0.07 log units), on the high side, within the range that was stated.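

Replacing ethoxy with methyl on the carbonyl carbon, a change that can also be read as ethoxycarbonyl to acetyl, again strengthens growth inhibition in this assay, giving a 4.4-fold lower number from compound 2 to compound 4 (0.64 log units; beyond the scatter). On the two cores shown, the change therefore carries over with much the same size: the same change on two cores in this assay, a 3.7-fold lower number (0.57 log units; beyond the scatter) from compound 1 to compound 3 and a 4.4-fold lower number (0.64 log units; beyond the scatter) from compound 2 to compound 4, 1.2-fold (0.07 log units) apart, within the scatter of two such steps. For the compounds shown here, this shows that the step can be moved between these two closely related cores, but with only two pairs it does not show that the same size would hold on any other core, and the numbers alone do not explain why the change strengthens inhibition.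

The compounds shown put only ethoxy and methyl on this carbonyl carbon, so it remains open how a longer chain such as propyl, an amine or a carboxylic acid would read there. From the compounds shown here alone, it is also open whether the step would keep its size on a core changed somewhere else in the molecule.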